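Chain Extension on a Urea Series Measured for Cell Growth

A few compounds are considered here, and "the series" means these few. Any claim that something is new, unique, unknown or untested is made for them only; others in the source may bear on it.

Compound 1 `CC(=O)Nc1cccc(S(=O)(=O)Oc2ccccc2C(C)C)c1` and compound 2 `CCCC(=O)Nc1cccc(S(=O)(=O)Oc2ccccc2C(C)C)c1` share one core, while compound 3 `CCCNC(=O)Nc1ccc(S(=O)(=O)Oc2ccccc2C(C)C)cc1` and compound 4 `CCCCCNC(=O)Nc1ccc(S(=O)(=O)Oc2ccccc2C(C)C)cc1` share another; the difference between the two cores is not broken down here. In a functional assay on M21 cells (Homo sapiens) for antiproliferative activity, read by sulforhodamine B assay, with a stated time of 48 h (a lower number here means a stronger inhibitor, a higher number a weaker inhibitor), compound 1 gives 31000 nM, compound 2 gives 20000 nM, and compound 3 gives 5100 nM. Compound 2 arises from compound 1 by ethyl in place of hydrogen on a saturated chain carbon bound to a carbonyl carbon, a step of a 1.6-fold lower number from compound 1 to compound 2 (0.19 log units; within the scatter). Compound 4 arises from compound 3 by ethyl in place of hydrogen on a saturated chain carbon, three bonds along the chain from an amide-type nitrogen; this is the same kind of change, but the place differs, lying three bonds along the chain from an amide-type nitrogen rather than bound to a carbonyl carbon. Because the earlier step was a 1.6-fold lower number from compound 1 to compound 2 (0.19 log units; within the scatter), the step from compound 3 to compound 4 in this assay is expected to be small, about a 1.3-fold lower number from compound 3 to compound 4 (0.11 log units; within the scatter). Compound 4 is therefore estimated at 4000 nM, between 1500 nM and 11000 nM.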

Compound 4, half-maximal inhibitory concentration: 4600 nM
The estimate for compound 4 lay 1.2-fold (0.06 log units) below the measured number, within the range that was stated.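

In this assay the new step is a 1.1-fold lower number from compound 3 to compound 4 (0.04 log units; within the scatter), so putting ethyl in place of hydrogen leaves the number of this pair effectively unchanged. Set beside the earlier step, the same change behaves alike on the two cores, even though it sits at a different place on the chain in each: the same change on two cores in this assay, a 1.6-fold lower number (0.19 log units; within the scatter) from compound 1 to compound 2 and a 1.1-fold lower number (0.04 log units; within the scatter) from compound 3 to compound 4, 1.4-fold (0.15 log units) apart, within the scatter of two such steps This supports only the modest statement that the change stayed small in these two pairs; it does not show that chain length has any real effect, and two pairs make no rule for the whole series.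

From the compounds shown here alone, whether a much longer chain, or a chain ending in an amine or a carboxylic acid, would move the number beyond the scatter remains open. Going by these compounds, what a phenyl ring in place of the chain would do on either core also remains open.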